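Azole exchange at the benzylic carbon of compound 1

The compounds below may be only part of what the source reports. "The series", "measured", "known", "first", "only" and "open" are said of these compounds alone.

In an assay on membranes from uterus for displacement of a labelled ligand from Angiotensin type II receptor (Sus scrofa), with a stated time of 1.5 h (on this read-out lower numbers stand for stronger inhibition and higher numbers for weaker inhibition), compound 1 `CCCCOC(=O)NS(=O)(=O)c1sc(CC(C)C)cc1-c1ccc(Cn2ncnn2)cc1` gives 16 nM, the higher of the two numbers here; the nearest is compound 2 `CCCCOC(=O)NS(=O)(=O)c1sc(CC(C)C)cc1-c1ccc(CN2CCCC2=O)cc1` at 3.5 nM, reached by a 4.6-fold lower number from compound 1 to compound 2 (0.66 log units; beyond the scatter). Compound 3 `CCCCOC(=O)NS(=O)(=O)c1sc(CC(C)C)cc1-c1ccc(CN2C(=O)CCC2=O)cc1` reaches only the limit > 10000 nM in this assay, (the limit of > 10000 nM in this assay, at which 1 of the 3 values shown sits). Compound 4 `CCCCOC(=O)NS(=O)(=O)c1sc(CC(C)C)cc1-c1ccc(Cn2cnc(C(F)(F)F)c2)cc1` carries 4-(trifluoromethyl)-1H-imidazol-1-yl in place of 2H-tetrazol-2-yl on a saturated chain carbon bound to an aromatic carbon. Both measured steps start from the same position: the move to the single carbonyl ring gave a 4.6-fold lower number from compound 1 to compound 2 (0.66 log units; beyond the scatter), the move to the dicarbonyl ring gave an at least 620-fold higher number from compound 1 to compound 3 (2.79 log units; beyond the scatter), and an at least 2800-fold higher number from compound 2 to compound 3 (3.45 log units; beyond the scatter) separates those two. Compound 4 keeps a five-membered aromatic ring there, so a change near or within the scatter is expected. Compound 4 is estimated at 20 nM, between 5 nM and 80 nM, meaning a 1.3-fold higher number from compound 1 to compound 4 (0.10 log units; within the scatter).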

Compound 4, inhibition constant: 7.3 nM
For compound 4 the middle estimate is 2.7-fold (0.44 log units) above the measured one, and the stated range covers the measured number.
By their numbers in this assay, from the lowest: compound 2; then compound 4; then compound 1. At a limit, above all of these: compound 3.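

At the saturated chain carbon bound to an aromatic carbon, 4-(trifluoromethyl)-1H-imidazol-1-yl, with more heavy atoms and fewer hydrogen-bond acceptors than 2H-tetrazol-2-yl, is accepted in this assay, with a 2.2-fold lower number from compound 1 to compound 4 (0.34 log units; beyond the scatter). The five-membered aromatic ring with a substituent therefore stays close to the single carbonyl ring, with a 2.1-fold higher number from compound 2 to compound 4 (0.32 log units; beyond the scatter), and far from the dicarbonyl ring, with an at least 1300-fold lower number from compound 3 to compound 4 (3.13 log units; beyond the scatter). The value of compound 3 is a limit of the assay: the limit of > 10000 nM in this assay, at which 1 of the 4 values shown sits.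

The compounds shown cannot tell whether the ring or the trifluoromethyl group sets the step from the tetrazole. A plain imidazol-1-yl or a methyl in place of trifluoromethyl would separate the two.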